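Dimethylamino to pyrrolidinyl on the chain of compound 2

A few compounds are considered here, and "the series" means these few. Any claim that something is new, unique, unknown or untested is made for them only; others in the source may bear on it.

Compound 2 `CN(C)CCCOc1c(OCc2ccccc2)cc(O)c2c(=O)cc(-c3ccccc3)oc12` gives 5420 nM in a functional assay on B16 cells (Mus musculus) for cytotoxicity, read by MTT assay, with a stated time of 72 h (on this read-out lower numbers stand for stronger inhibition and higher numbers for weaker inhibition), the higher of the two numbers measured; compound 1 `COc1c(OCCCCN2CCN(C)CC2)cc(O)c2c(=O)cc(-c3ccc(C(F)(F)F)cc3)oc12` gives 4990 nM in this assay, and the two lie within the scatter of each other. Compound 3 `O=c1cc(-c2ccccc2)oc2c(OCCCN3CCCC3)c(OCc3ccccc3)cc(O)c12` carries pyrrolidin-1-yl in place of dimethylamino on a saturated chain carbon, three bonds along the chain from an oxygen on an aromatic ring. Among the measured compounds shown here, no pair of measured compounds shows this change, so there is no basis for more than a small step in either direction in this assay. Compound 3 is therefore expected to give about 4500 nM, with a range from 2000 nM to 11000 nM, an estimated step of a 1.2-fold lower number from compound 2 to compound 3 (0.08 log units; within the scatter) not beyond the scatter.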

Compound 3, half-maximal inhibitory concentration: 7980 nM
Compound 3: middle estimate off by 1.8-fold (0.25 log units), on the low side; the range from low to high includes it.
By their numbers in this assay, from the lowest: compounds 1, 2 and 3 (each within the scatter of the next).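

Changing 3-(dimethylamino)propyl to 3-(pyrrolidin-1-yl)propyl gives a 1.5-fold higher number from compound 2 to compound 3 (0.17 log units; within the scatter) in this assay. Among the compounds shown here, this single pair is the first reading of this change at this position, and it shows that the five-membered ring can take the place of dimethylamino on this chain without a step beyond the scatter. No supporting data bear on this result.

On these data alone, whether piperidin-1-yl or morpholin-4-yl at this place, or a longer chain carrying pyrrolidin-1-yl, would move the number beyond the scatter remains open. So does whether the same change would give a similar step on another core.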